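HepG2 cytotoxicity notes on a shared-core series

The source may report more compounds than this note shows. Statements on the series, on what has been measured and on what is new or still open speak of the compounds shown alone.

Measured so far:
compound 1 `COc1ccc(F)cc1CNCCCNc1ccnc2cc(Cc3ccc(C#N)cc3)ccc12`: 6050 nM
compound 2 `COc1cccc(CNCCCNc2ccnc3cc(Oc4cccc(N(C)C)c4)ccc23)c1O`: 7300 nM
compound 3 `COc1ccc(F)cc1CNCCCNc1ccnc2cc(Cc3ccccc3)ccc12`: 7990 nM

In an ADME assay on HepG2 cells (Homo sapiens) for cytotoxicity, read by luminescence, CellTiter-Glo and ATP content, with a stated time of 72 h (on this read-out higher numbers stand for an effect only at larger amounts of compound and lower numbers for an effect already at smaller amounts), the three measured compounds sit close together. Compound 3 holds the highest of the three numbers, yet its gap to compound 2 and its gap to compound 1 both lie within the scatter. Among the measured compounds shown here, the single measured step, a 1.3-fold higher number from compound 1 to compound 3 (0.12 log units; within the scatter), is likewise within the scatter.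

Compound 4 `COc1ccc(F)cc1CNCCCNc1ccnc2cc(Oc3cccc(N(C)C)c3)ccc12` differs from compound 3 by 3-(dimethylamino)phenoxy in place of benzyl on an aromatic carbon. For the measured compounds named here, no measured step exchanges this group on the shared core; the cyano-to-hydrogen step touches another part, and compound 2, which carries the entering group with a different amine arm, lies close to compound 3. For compound 4 no step beyond the scatter is therefore expected in this assay. The expected step is a 1.1-fold lower number from compound 3 to compound 4 (0.06 log units; within the scatter). Compound 4 is estimated at 7000 nM, between 3500 nM and 14000 nM.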

Compound 4, half-maximal effective concentration: 3300 nM
Beside the measured number, compound 4's estimate is 2.1-fold (0.33 log units) above it; measured number outside the range, below it.
By their numbers in this assay, from the lowest: compounds 4, 1, 2 and 3 (each within the scatter of the next, the first and the last beyond it).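

In this assay, the exchange on this aromatic carbon now gives a step beyond the scatter, as 3-(dimethylamino)phenoxy in place of benzyl yields a 2.4-fold lower number from compound 3 to compound 4 (0.38 log units; beyond the scatter) and the same group in place of 4-cyanobenzyl yields a 1.8-fold lower number from compound 1 to compound 4 (0.26 log units; within the scatter) and stays within it. With 3-(dimethylamino)phenoxy held fixed, the amine arm also registers: 5-fluoro-2-methoxyphenyl in place of 2-hydroxy-3-methoxyphenyl gives a 2.2-fold lower number from compound 2 to compound 4 (0.34 log units; beyond the scatter) and lies beyond the scatter. Nothing available accounts for either modest step.

Open, from the compounds shown here alone, is whether the dimethylamino group itself matters, which a plain phenoxy or a morpholine in its place would test.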